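The source may hold more compounds than are shown below. What is called first, only, known or untested is meant among the compounds shown, and "the series" means these compounds.

Measured compounds:
- compound 1 `Cc1ccc2cc(/C=C/C(=O)c3ccc(Br)s3)c(Cl)nc2c1` gives 83.6 nM in a functional assay on HUVEC cells (Homo sapiens), read by BrdU incorporation, with a stated time of 72 h; a higher number here means a weaker inhibitor, a lower number a stronger inhibitor
- compound 2 `Cc1cccc2cc(/C=C/C(=O)c3ccc(Br)s3)c(Cl)nc12` gives 243 nM in this assay
- compound 3 `Cc1ccc2cc(/C=C/C(=O)c3ccc(Cl)s3)c(Cl)nc2c1` gives 49.5 nM in this assay

Compound 1 and compound 2 are built from the same atoms joined differently; the difference between the two cores is not broken down here. On compound 1's core, one change has been measured: chloro in place of bromo on an aromatic carbon. This change gave a 1.7-fold lower number from compound 1 to compound 3 (0.23 log units; within the scatter), a step that stays within the usual scatter of repeated measurements, so compound 1 and compound 3 cannot be told apart with confidence.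

Compound 4 `Cc1cccc2cc(/C=C/C(=O)c3ccc(Cl)s3)c(Cl)nc12` has not yet been measured. Going by the values given here, it carries compound 2's core and differs from compound 2 by chloro in place of bromo on an aromatic carbon, the same change, at the same place, as the one between compound 1 and compound 3. Compound 2 gives the highest number of the three, a gap beyond the scatter to both compound 1 and compound 3.

Among the compounds with values here, on the one measured example, the step from compound 2 to compound 4 is expected to be a 1.6-fold lower number from compound 2 to compound 4 (0.21 log units; within the scatter), resting on a 1.7-fold lower number from compound 1 to compound 3 (0.23 log units; within the scatter) applied to compound 2's 243 nM. Compound 4 is therefore estimated at 150 nM, with a plausible range from 70 nM to 320 nM.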

Compound 4, half-maximal inhibitory concentration: 116 nM
Compound 4: the middle estimate sits 1.3-fold (0.11 log units) above what was measured; the range from low to high includes it.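

Putting 5-chlorothiophen-2-yl in place of 5-bromothiophen-2-yl gave a 2.1-fold lower number from compound 2 to compound 4 (0.32 log units; beyond the scatter) in this assay. The earlier step on the other core points the same way, and the two steps do not differ in size: the same change on two cores in this assay, a 1.7-fold lower number (0.23 log units; within the scatter) from compound 1 to compound 3 and a 2.1-fold lower number (0.32 log units; beyond the scatter) from compound 2 to compound 4, 1.2-fold (0.09 log units) apart, within the scatter of two such steps

Within this pair of cores, then, the change carried over with much the same size, even though the earlier step alone cannot separate its two compounds; two examples do not show that it would hold on any other core, and they do not explain why the change has this result.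

The compounds shown carry only bromo and chloro at this place on the thiophene, which leaves open what a methyl, a nitrile or an amine there would give. On these data alone, neither the methyl nor the chloro on the cores is replaced by another group here, so the result of a methoxy or a plain hydrogen in their place also remains unknown.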